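A Silyl Ether in Place of Methoxy: Limit Expected Again

A few compounds are considered here, and "the series" means these few. Any claim that something is new, unique, unknown or untested is made for them only; others in the source may bear on it.

Compound 1 `Nc1cc(-c2ccccc2)ccc1NC(=O)c1ccc(CNc2nccc(-c3cccnc3)n2)cc1` in an assay for inhibition of histone deacetylase 8 (Homo sapiens), read by fluorescence, with stated times of 15 min and 60 min (on this read-out higher numbers stand for weaker inhibition and lower numbers for stronger inhibition), gives > 20000 nM, a limit of the assay.
Compound 2 `COc1ccc(NC(=O)c2ccc(CNc3nccc(-c4cccnc4)n3)cc2)c(N)c1` in this assay gives > 20000 nM, also a limit.

Compound 2 therefore stands at the ceiling of the readable range, and the step that the two limits leave unreadable from compound 1 to compound 2 cannot be sized, both numbers sitting at the limit of > 20000 nM in this assay, at which 2 of the 2 values shown sit. Compound 3 `CC(C)(C)[Si](C)(C)OCc1ccc(NC(=O)c2ccc(CNc3nccc(-c4cccnc4)n3)cc2)c(N)c1` carries a group of 9 heavy atoms (7 carbon, 1 oxygen, 1 silicon; no ring) in place of a group of 2 heavy atoms (1 carbon, 1 oxygen; no ring), on an aromatic carbon. For the measured compounds named here, no measured step gives a readable size, so compound 3 is expected to remain at the limit, with an expected step that the limit leaves unreadable from compound 2 to compound 3 not readable beyond the scatter. Compound 3 is estimated at 25000 nM, between 6000 nM and 100000 nM.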

Compound 3, half-maximal inhibitory concentration: > 20000 nM
Compound 3: only a limit was reported; the forecaster's own chance of this, stated with the estimate: 85%; the middle value is on the limit's open side.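

Compound 3 gives > 20000 nM in this assay, a limit of the assay. For the compounds shown here, no step among compound 1, compound 2 and compound 3 can be read: the limit of > 20000 nM in this assay, at which 3 of the 3 values shown sit. The compounds shown leave open whether any of these groups changes inhibition at all.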